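The source may hold more compounds than are shown below. What is called first, only, known or untested is meant among the compounds shown, and "the series" means these compounds.

Measured so far in a functional assay on PC-3 cells (Homo sapiens) for inhibition, read by sulforhodamine B assay, with a stated time of 48 h; on this read-out lower numbers stand for stronger inhibition of growth and higher numbers for weaker inhibition of growth:

- Compound 1 `CCOC(=O)c1nn(-c2ccc(Cl)cc2)c(-c2ccc(C)cc2)c1CNC(C)(C)C`: 249000 nM; > 542000 nM (2 entries)
- Compound 2 `CC(C)(C)NCc1c(C(=O)O)nn(-c2ccc(Cl)cc2)c1-c1ccc(Br)cc1`: > 542000 nM

Compound 1 has two entries, one a number and the other a limit. Compound 2 has no single number in this assay, only the limit > 542000 nM.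

Compound 3 `Cc1ccc(-c2c(CNC(C)(C)C)c(C(=O)O)nn2-c2ccc(Cl)cc2)cc1` differs from compound 2 in one place, 4-bromophenyl to 4-methylphenyl: methyl in place of bromo on an aromatic carbon, para to a large group (methyl in place of bromo on an aromatic carbon).

Among the compounds with values here, no measured step shows what this swap does, so no shift beyond the usual scatter is expected in this assay, in either direction. Compound 2, with its limit of > 542000 nM, gives the only anchor for this expectation. The expected change is an at least 1.0-fold lower number from compound 2 to compound 3 (0.03 log units; that floor lies within the scatter). For compound 3 the estimated value is 500000 nM. The expected range for compound 3 runs from 180000 nM to 1000000 nM, and a report of only a limit is quite likely.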

Compound 3, concentration for 50% growth inhibition: > 629000 nM
Compound 3 gave a limit, no number; the forecaster's own chance of this, stated with the estimate: 65%; middle value at least 1.2-fold (0.09 log units) from the limit.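

In this assay, compound 2 and compound 3 are each reported only as a limit, not as a number, so the step between them cannot be read. The compounds shown leave open whether 4-methylphenyl in place of 4-bromophenyl changes growth inhibition at all.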